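Swapping bromo for chloro on two related oxindole-type scaffolds

The source may hold more compounds than are shown below. What is called first, only, known or untested is meant among the compounds shown, and "the series" means these compounds.

Measured compounds:
compound 1, `O=C1C(=O)N(CN(c2ccccc2)c2ccccc2)c2cccc(Cl)c21`, with 29700 nM in a functional assay on MCF7 cells (Homo sapiens) for cytotoxicity, read by sulforhodamine B assay, with a stated time of 48 h; on this read-out lower numbers stand for stronger inhibition of growth and higher numbers for weaker inhibition of growth;
compound 2, `Cc1ccc2nc(/N=C3\C(=O)N(CN(c4ccccc4)c4ccccc4)c4cccc(Br)c43)sc2c1`, with 30200 nM in this assay;
compound 3, `O=C1C(=O)N(CN(c2ccccc2)c2ccccc2)c2cccc(Br)c21`, with 110000 nM in this assay.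

Compounds 1 and 3 share one core and differ only by chloro in place of bromo on an aromatic carbon. That change gives a 3.7-fold lower number from compound 3 to compound 1 (0.57 log units; beyond the scatter). Compound 2 carries a different core; the difference between the two cores is not broken down here, and on the numbers alone compound 2 sits close to compound 1 and well apart from compound 3.

Compound 4, `Cc1ccc2nc(/N=C3\C(=O)N(CN(c4ccccc4)c4ccccc4)c4cccc(Cl)c43)sc2c1`, is not yet measured. It differs from compound 2 by chloro in place of bromo on an aromatic carbon, the same change as from compound 3 to compound 1, at the same kind of place. Resting on a single earlier instance, compound 4 is expected to show a 2.7-fold lower number from compound 2 to compound 4 (0.44 log units; beyond the scatter) in this assay, somewhat more cautious than the earlier step. Compound 4 is therefore estimated at 11000 nM, between 3500 nM and 35000 nM.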

Compound 4, concentration for 50% growth inhibition: 24300 nM
Beside the measured number, compound 4's estimate is 2.2-fold (0.34 log units) below it; the range from low to high includes it.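

In this assay, putting chloro in place of bromo gives a 1.2-fold lower number from compound 2 to compound 4 (0.09 log units; within the scatter), so on this core the swap makes no difference that can be told apart from repeat scatter. The size of the step did not carry over from one core to the other: the same change on two cores in this assay, a 3.7-fold lower number (0.57 log units; beyond the scatter) from compound 3 to compound 1 and a 1.2-fold lower number (0.09 log units; within the scatter) from compound 2 to compound 4, 3.0-fold (0.47 log units) apart, beyond the scatter of two such steps. The earlier step therefore cannot simply be added on when moving to a new core in this series, but two pairs do not show why the cores differ or how the swap would behave on a third core.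

The compounds shown leave open what other groups at this place on the aromatic ring, such as fluoro, methyl or an amine, would do. They also leave open whether the gap between the two cores would hold in another cell line.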